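The source may report more compounds than this note shows. Statements on the series, on what has been measured and on what is new or still open speak of the compounds shown alone.

For the measured compounds named here, in a functional assay on HO8910 cells (Homo sapiens) for inhibition, read by MTT assay, with a stated time of 24 h, tested at 10 ug/mL (on this read-out higher numbers stand for more inhibition of growth at the one concentration tested and lower numbers for less inhibition of growth), compound 1 (`O=C(CCCCC1CCSS1)Nc1ccc(Cl)cn1`) gives 27.5% and compound 2 (`O=C(CCCCC1CCSS1)Nc1ccc(Br)cn1`) gives 29.6%, so compound 2 stands within the scatter of the only other measured compound. Compound 3 (`O=C(CCCCC(S)CCS)Nc1ccc(Br)cn1`) differs from compound 2 in one place: a group of 5 heavy atoms (3 carbon, 2 sulfur; no ring) in place of a group of 5 heavy atoms (3 carbon, 2 sulfur; one five-membered non-aromatic ring with 2 hetero atoms), on a saturated chain carbon, four bonds along the chain from a carbonyl carbon. The 1,3-disulfanylpropyl group enters on a saturated chain carbon, four bonds along the chain from a carbonyl carbon, and has no ring. Going by the values given here, the only measured step, a number 2.1 percentage points higher from compound 1 to compound 2 (within the scatter), is bromo in place of chloro on an aromatic carbon and does not touch this place. It therefore gives no size or direction for the new change, and the working expectation in this assay is no step beyond the scatter. For compound 3 the estimated value is 30%, with an expected range of 15% to 45%. This estimate means an expected a number 0.4 percentage points higher from compound 2 to compound 3 (within the scatter).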

Compound 3, percent growth inhibition at one concentration: 29.4%
The estimate for compound 3 lay 0.6 percentage points above the measured number; measured number inside the range.
By their numbers in this assay, from the lowest: compounds 1, 3 and 2 (each within the scatter of the next).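

In this assay, the open 1,3-disulfanylpropyl group in place of the group with the five-membered non-aromatic ring gives a number 0.2 percentage points lower from compound 2 to compound 3 (within the scatter). For the compounds shown here, this is the first reading at the saturated chain carbon, four bonds along the chain from a carbonyl carbon: the closed ring and the open chain are not told apart here, even though the entering group counts 2 hydrogen-bond donors and the leaving group 0. No measured evidence bears on this result.

Open still is whether this holds with chloro in place of bromo on the shared core, since the open form is shown only with bromo. Also open, as far as these compounds go, is what a carboxylic acid, an amine or a longer chain at this place would give in this assay.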